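From a Hydroxypropyl Chain to an Oxolane Ring

This account rests on a few compounds, and the source may have more. Where it says the series, first, only, none or still open, it means among the compounds named here.

Compound 2 `CN1C(=S)[C@@H](NC(=O)c2nc(Cc3ccccc3)n(CCCO)n2)COc2ccccc21` gives the lowest of the two numbers measured in a functional assay on HT-29 cells (Homo sapiens) for inhibition, read by luminescence and CellTiter-Glo, with a stated time of 24 h (a lower number here means that less compound is needed, a higher number that more compound is needed for the effect), where compound 2 gives 209 nM. For the measured compounds named here, its nearest neighbour is compound 1 `CN1C(=S)[C@@H](NC(=O)c2nc(Cc3ccccc3)n(CCCF)n2)COc2ccccc21`, which in this assay gives 4760 nM; the only measured step is a 23-fold lower number from compound 1 to compound 2 (1.36 log units; beyond the scatter). Compound 3 `CN1C(=S)[C@@H](NC(=O)c2nc(Cc3ccccc3)n(C3CCOC3)n2)COc2ccccc21` has not yet been measured. It differs from compound 2 in one place: oxolan-3-yl in place of 3-hydroxypropyl on an aromatic nitrogen. Going by the values given here, the one step that bears on this change shows that a hydroxy in place of a fluoro on that chain brought a large gain, and compound 3 gives up that hydrogen-bond donor while keeping one hydrogen-bond acceptor inside a ring. Because a 23-fold lower number from compound 1 to compound 2 (1.36 log units; beyond the scatter) was large, a step back toward a higher number, smaller than that step, is expected for compound 3. The expected step for compound 3 is a 5.7-fold higher number from compound 2 to compound 3 (0.76 log units; beyond the scatter). Compound 3 is therefore estimated at 1200 nM, with a range from 300 nM to 5000 nM.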

Compound 3, half-maximal effective concentration: 1580 nM
The estimate for compound 3 lay 1.3-fold (0.12 log units) below the measured number; measured number inside the range.
By their numbers in this assay, from the lowest: compound 2; then compound 3; then compound 1.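

In this assay, replacing the open chain with the ring gives a 7.6-fold higher number from compound 2 to compound 3 (0.88 log units; beyond the scatter), yet oxolan-3-yl still improves on 3-fluoropropyl, with a 3.0-fold lower number from compound 1 to compound 3 (0.48 log units; beyond the scatter). For the compounds shown here, the result at this aromatic nitrogen is therefore graded rather than all-or-nothing: oxolan-3-yl, with 0 hydrogen-bond donors and 1 hydrogen-bond acceptor, falls in the middle, while 3-hydroxypropyl, the only one of the three groups with a hydrogen-bond donor, gives the lowest number. No supporting evidence explains this order.

Compound 3 loses the hydroxy and gains a ring in a single change, so the effect of each remains unseparated; an open 3-methoxypropyl chain would help to tell them apart. On these data alone, how an amine at the end of the propyl chain or a longer hydroxyalkyl chain would compare also remains open.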